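Debenzylation of Compound 3: What to Expect of Compound 4

This account rests on a few compounds, and the source may have more. Where it says the series, first, only, none or still open, it means among the compounds named here.

Compound 1 `C[Si](C)(C)CCOCn1c(CC(O)(COCc2ccccc2)COCc2ccccc2)cc(=O)[nH]c1=O`: in a functional assay on MCF7 cells (Homo sapiens) for antiproliferative activity, read by MTT assay, with a stated time of 72 h (a higher number here means a weaker inhibitor, a lower number a stronger inhibitor), compound 1 gives > 100000 nM, which is a limit of the assay.
Compound 2 `C[Si](C)(C)CCOCn1c(CC(O)(CO)CO)cc(=O)[nH]c1=O`: in this assay compound 2 gives > 100000 nM, also a limit.
Compound 3 `C[Si](C)(C)CCOCn1c(CC(O)COCc2ccccc2)cc(=O)[nH]c1=O`: in this assay compound 3 gives > 100000 nM, again a limit.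

Compound 3 therefore stands nowhere on a scale of numbers: its value is a limit, and the same is true of the other two values, since all three sit at the limit of > 100000 nM in this assay, at which 3 of the 3 values shown sit. Within the data shown here, the one measured step that touches compound 3, a step that the two limits leave unreadable from compound 1 to compound 3, is unreadable for that reason, and the values of compound 1 and compound 2 show only that both are limits as well.

Compound 4 `C[Si](C)(C)CCOCn1c(CC(O)CO)cc(=O)[nH]c1=O` differs from compound 3 by hydrogen in place of benzyl on an oxygen on a saturated carbon. Among the measured compounds shown here, the step from compound 1 to compound 3 is the only measured change that resembles it, and it gives no size, so no step beyond the scatter can be read from it in either direction. The expectation for compound 4 is thus that this assay again reports a limit, with the step that the limit leaves unreadable from compound 3 to compound 4 expected to be nominal. Compound 4 is estimated at 150000 nM, within 50000 nM to 500000 nM.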

Compound 4, half-maximal inhibitory concentration: > 100000 nM
Compound 4: no number, only a limit; the forecaster's own chance of this, stated with the estimate: 85%; the middle value lies beyond the limit too.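

In this assay compound 4 gives > 100000 nM as a limit of the assay. Among these compounds, no step to compound 4 from compound 2 or compound 3 can be read, since all values shown are limits: the limit of > 100000 nM in this assay, at which 4 of the 4 values shown sit. In this assay the compounds shown leave open which change to the shared core, if any, would give a readable value.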